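Taking one methyl from compound 3

This account rests on a few compounds, and the source may have more. Where it says the series, first, only, none or still open, it means among the compounds named here.

In a functional assay for inhibition, with Rattus norvegicus as the target (a higher number here means a weaker inhibitor, a lower number a stronger inhibitor), compound 1 (`CCCCc1c(CCCC)c(OC(C)=O)c2ccccc2c1OC`) gives 6020 nM and compound 3 (`CCCCc1cc(OC)c2c(C)cc(C)c(C)c2c1OC(C)=O`) gives 11900 nM, two numbers within the scatter of each other. Compound 2 (`CCCCCc1c(C(=O)OCC)c(OC)c2ccccc2c1OC(C)=O`) gives 940 nM, a number beyond the scatter from that of compound 3, which therefore stands at the high end of this small set. Compound 4 (`CCCCc1cc(OC)c2c(C)ccc(C)c2c1OC(C)=O`) differs from compound 3 in one place: hydrogen in place of methyl on an aromatic carbon. Among the measured compounds shown here, no measured pair differs in only one place, so this assay offers no direct precedent. A small move toward a lower number is expected, probably not beyond the scatter, and the estimated change is a 1.3-fold lower number from compound 3 to compound 4 (0.12 log units; within the scatter). Compound 4 is expected at 9000 nM, within a range of 3500 nM to 20000 nM.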

Compound 4, half-maximal inhibitory concentration: 7350 nM
Estimate against measurement, compound 4: 1.2-fold (0.09 log units) above, and the stated range covers the measured number.
By their numbers in this assay, from the lowest: compound 2; then compounds 1, 4 and 3 (each within the scatter of the next).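

In this assay, among the compounds shown here, the first step between two compounds that differ in one place is a 1.6-fold lower number from compound 3 to compound 4 (0.21 log units; within the scatter) and it lies within the scatter. Hydrogen in place of methyl on this aromatic carbon, ortho to a methyl group, therefore produces no change that can be told from scatter. No measurement offered here explains this result. The compounds shown leave open whether removing the other methyl groups would likewise stay within the scatter. They also leave open what an ethyl group, a methoxy group or an amine on this carbon would do.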